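The source may hold more compounds than are shown below. What is called first, only, known or untested is meant among the compounds shown, and "the series" means these compounds.

Among the compounds with values here, in a functional assay on MeWo cells (Homo sapiens) for cytotoxicity, read by MTT assay, with a stated time of 48 h (on this read-out lower numbers stand for stronger inhibition and higher numbers for weaker inhibition), the series so far holds two numbers. Compound 1 (`COc1cc(/C=C/c2cc(-c3ccc(O)c(OC)c3)[nH]n2)ccc1O`) gives 3700 nM and compound 2 (`COc1cc(/C=C/c2cc(-c3ccc(O)c(OC)c3)[nH]n2)cc(OC)c1`) gives 4800 nM in the same read-out. Compound 2 therefore stands within the scatter of compound 1, and the two values cannot be ranked. Going to compound 3 (`COc1cccc(/C=C/c2cc(-c3ccc(O)c(OC)c3)[nH]n2)c1`), hydrogen takes the place of methoxy on an aromatic carbon (hydrogen in place of methoxy on an aromatic carbon). Within the data shown here, no step between measured compounds that differ in one place is available, so nothing measured shows what this change does. The expectation rests only on the narrow span of the two values to date. In this assay no step beyond the scatter is expected, in either direction. The estimated step is a 1.0-fold higher number from compound 2 to compound 3 (0.02 log units; within the scatter) in size. The estimate for compound 3 is 5000 nM with an expected range from 2300 nM to 11000 nM in this read-out.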

Compound 3, half-maximal inhibitory concentration: 3600 nM
The estimate for compound 3 lay 1.4-fold (0.14 log units) above the measured number; measured number inside the range.
By their numbers in this assay, from the lowest: compounds 3, 1 and 2 (each within the scatter of the next).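

In this assay, hydrogen in place of methoxy on an aromatic carbon gives a 1.3-fold lower number from compound 2 to compound 3 (0.12 log units; within the scatter), and the loss of the hydroxy gives a 1.0-fold lower number from compound 1 to compound 3 (0.01 log units; within the scatter); both steps lie within the scatter. Within the data shown here, these are the first one-place changes, and they show that neither substituent moves the read-out measurably at its place on this six-membered aromatic ring, with the one remaining methoxy giving values in the same band. No evidence bearing on this result is at hand.

As far as these compounds go, whether an amine or a carboxylic acid on this aromatic carbon, or a longer chain such as butoxy, would also stay within the scatter remains open. Also open, from the compounds shown here alone, is what happens when the remaining methoxy is replaced by hydrogen, and how the hydroxy and methoxy elsewhere on the shared core contribute.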